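This account rests on a few compounds, and the source may have more. Where it says the series, first, only, none or still open, it means among the compounds named here.

Measured so far in the series:

Compound 1 `Cc1nnsc1CO/N=C/c1c(C)nn(C)c1Oc1ccccc1Cl` gives 42500 nM in a functional assay on HCT-116 cells (Homo sapiens) for inhibition, read by MTT assay, with a stated time of 48 h; a higher number here means a weaker inhibitor, a lower number a stronger inhibitor.
Compound 2 `CCc1nnsc1CO/N=C/c1c(C)nn(C)c1Oc1ccccc1Cl` gives 17600 nM in this assay.
Compound 3 `CCc1nnsc1CO/N=C/c1c(C)nn(C)c1Cl` reaches only a limit of this assay, > 50000 nM.

The change from compound 1 to compound 2 is methyl in place of hydrogen on a saturated chain carbon bound to an aromatic carbon, and it made a 2.4-fold lower number from compound 1 to compound 2 (0.38 log units; beyond the scatter). The next change made an at least 2.8-fold higher number from compound 2 to compound 3 (0.45 log units; beyond the scatter), so that compound 3 sits at the limit of > 50000 nM in this assay, at which 1 of the 3 values shown sits. The difference between the core of compound 1 and the core of compound 3 is not broken down here.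

Compound 4 `CCCc1nnsc1CO/N=C/c1c(C)nn(C)c1Cl` is not yet measured. It differs from compound 3 by methyl in place of hydrogen on a saturated chain carbon, two bonds along the chain from an aromatic carbon. This is the same kind of change as from compound 1 to compound 2, not the same: there the entering methyl sits on a saturated chain carbon bound to an aromatic carbon, here on a saturated chain carbon two bonds along the chain from an aromatic carbon. The expectation for compound 4 rests on a 2.4-fold lower number from compound 1 to compound 2 (0.38 log units; beyond the scatter), a modest step, and on compound 3 standing at a limit. For compound 4 the expected step in this assay is an at least 1.1-fold lower number from compound 3 to compound 4 (0.04 log units; that floor lies within the scatter). Compound 4 is estimated at 45000 nM, between 15000 nM and 150000 nM, with a real chance that only a limit is reported again.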

Compound 4, half-maximal inhibitory concentration: > 50000 nM
Compound 4: only a limit was reported; the forecaster's own chance of this, stated with the estimate: 60%; at least 1.1-fold (0.04 log units) between middle value and limit.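

Compound 4 reaches only a limit in this assay, > 50000 nM, and compound 3 also stands at a limit, so no step between compound 3 and compound 4 can be read: the limit of > 50000 nM in this assay, at which 2 of the 4 values shown sit.

The compounds shown leave open whether ethyl to propyl changes the number at all, with either chloro or 2-chlorophenoxy in place.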